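Ester variation on a shared core: expected cytotoxicity

The compounds below may be only part of what the source reports. "The series", "measured", "known", "first", "only" and "open" are said of these compounds alone.

Measured compounds:
compound 1 `C=CCn1c(=O)c(CCO)c(-c2ccccc2Cl)c2cc(Cl)ccc21`, 23000 nM
compound 2 `CC(=O)N1CCC(C(=O)OCCc2c(-c3ccccc3Cl)c3cc(Cl)ccc3[nH]c2=O)CC1`, 82000 nM

Of the compounds shown here, two on the shared core have been tested in an ADME assay on HepG2 2.2.15 cells (Homo sapiens) for cytotoxicity; on this read-out higher numbers stand for lower toxicity in this test and lower numbers for higher toxicity in this test. Compound 1 gives 23000 nM, and compound 2 gives 82000 nM. Compound 2 therefore stands at the higher of the two numbers, with compound 1 the nearer and lower one, a gap that lies beyond the scatter.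

Compound 3 `COc1ccc(/C=C/C(=O)OCCc2c(-c3ccccc3Cl)c3cc(Cl)ccc3[nH]c2=O)cc1OC` has not yet been measured. It differs from compound 2 in one place: 2-(3,4-dimethoxyphenyl)ethenyl in place of 1-acetylpiperidin-4-yl on a carbonyl carbon. Within the data shown here, no pair of measured compounds traces this change, so the two values above are the only guide.

Compound 3 is expected to lie between the two measured numbers, at 50000 nM with a range of 15000 nM to 150000 nM. The expected step of a 1.6-fold lower number from compound 2 to compound 3 (0.21 log units; within the scatter) is a modest move downwards, not clearly beyond the scatter.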

Compound 3, half-maximal cytotoxic concentration: > 1200000 nM
Compound 3: no number, only a limit; the forecaster's own chance of this, stated with the estimate: 25%; middle value at least 24-fold (1.38 log units) from the limit.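

In this assay, the group on the carbonyl carbon proves able to move the read-out far more than the two earlier values suggested: 2-(3,4-dimethoxyphenyl)ethenyl in place of 1-acetylpiperidin-4-yl gives an at least 14-fold higher number from compound 2 to compound 3 (1.16 log units; beyond the scatter). This is the first single-place change shown, and it moves the read-out towards lower toxicity in this test, something compound 1 and compound 2 could not show, as they differ in more than one place. The reading for compound 3 is a limit and not a number: the limit of > 1200000 nM in this assay, at which 1 of the 3 values shown sits.

The full size of the step therefore stays open, and the compounds shown do not separate the contribution of the dimethoxyphenyl ring from that of the ethenyl link. As far as these compounds go, what an unsubstituted phenyl, a longer saturated chain or an amine on this carbonyl carbon would give also remains open.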